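Swapping the Aryl Group on a Carbamate Nitrogen

This account rests on a few compounds, and the source may have more. Where it says the series, first, only, none or still open, it means among the compounds named here.

Of the compounds shown here, three built on one shared core have been tested in a functional assay on PANC-1 cells (Homo sapiens) for inhibition, read by MTT assay, with a stated time of 24 h, tested at 10 uM; a higher number here means more inhibition at the concentration tested (going by the name of the read-out), a lower number less inhibition. Compound 1 `COc1ccc(NC(=O)Oc2cc(=O)n(CCCO)c3c2CC(C/C=C(\C)CCC=C(C)C)C(C)(C)C3)cc1` gives 64.1%. Compound 2 `CC(C)=CCC/C(C)=C/CC1Cc2c(OC(=O)Nc3ccc(F)c(F)c3)cc(=O)n(CCCO)c2CC1(C)C` gives 43.7%, and compound 3 `CC(C)=CCC/C(C)=C/CC1Cc2c(OC(=O)Nc3cccc(C(F)(F)F)c3)cc(=O)n(CCCO)c2CC1(C)C` gives 44%. Among these three numbers compound 3 stands second highest; its nearest neighbour is compound 2, within the scatter, while compound 1 lies furthest from it, beyond the scatter. The two measured drops from the top were a number 20.4 percentage points lower from compound 1 to compound 2 (beyond the scatter) and a number 20.1 percentage points lower from compound 1 to compound 3 (beyond the scatter), whereas a number 0.3 percentage points higher from compound 2 to compound 3 (within the scatter).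

Compound 4 `CC(C)=CCC/C(C)=C/CC1Cc2c(OC(=O)Nc3ccc(Cl)c(Cl)c3)cc(=O)n(CCCO)c2CC1(C)C` is the next variation: 3,4-dichlorophenyl in place of 3-(trifluoromethyl)phenyl on an amide-type nitrogen. Going by the values given here, the step that bears most on this change is the one between compound 2 and compound 3, where exchanging one ring for another left the number unchanged within the scatter. Among the compounds with values here, no measured step involves a 3,4-dichlorophenyl group, so the expectation rests on that single comparison. The expected step is a number 1 percentage points higher from compound 3 to compound 4 (within the scatter), meaning no change beyond the scatter. Compound 4 is therefore estimated at 45%, within a range from 30% to 60%.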

Compound 4, a percentage reported as inhibition, at one concentration (the size of the read-out at that concentration, not a potency): 20%
Estimate against measurement, compound 4: 25 percentage points above; the whole stated range lies above it.
By their numbers in this assay, from the lowest: compound 4; then compounds 2 and 3 (each within the scatter of the next); then compound 1.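

In this assay, going by these compounds alone, the aryl group on the amide-type nitrogen proves less forgiving than the earlier compounds suggested: 3,4-dichlorophenyl gives a number 24 percentage points lower from compound 3 to compound 4 (beyond the scatter) and a number 23.7 percentage points lower from compound 2 to compound 4 (beyond the scatter) even though the two rings it is compared with showed no difference beyond the scatter. The second of these steps exchanges only fluorine for chlorine, so the identity of the halogen matters in this series. Within the data shown here, the largest step so far, a number 44.1 percentage points lower from compound 1 to compound 4 (beyond the scatter), shows how widely this one position can move the number, but nothing measured here explains the drop.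

As far as these compounds go, it remains open whether a single chlorine, as in 4-chlorophenyl, is enough to cause the fall. A 3,4-dimethoxyphenyl or 4-aminophenyl ring would test whether the higher number of compound 1 extends beyond its 4-methoxyphenyl group.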